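Swapping the 2-Fluorophenyl Ring of Compound 3 for 3-Methylphenyl

A few compounds are considered here, and "the series" means these few. Any claim that something is new, unique, unknown or untested is made for them only; others in the source may bear on it.

Of the compounds shown here, three have been measured in an assay on cells for agonist activity at ecdysone receptor (Bombyx mori), read by a luciferase reporter, with a stated time of 24 h; on this read-out higher numbers stand for an effect only at larger amounts of compound and lower numbers for an effect already at smaller amounts. Compound 1 `CC(C)(C)N(NC(=O)c1ccccc1)C(=O)c1ccccc1I` gives 105 nM, compound 2 `Cc1cc(C)cc(C(=O)N(NC(=O)c2ccccc2)C(C)(C)C)c1` gives 69.2 nM, and compound 3 `CC(C)(C)N(NC(=O)c1ccccc1F)C(=O)c1ccccc1Cl` gives 51.3 nM. For the measured compounds named here, the single one-place step on record, a 1.5-fold lower number from compound 1 to compound 2 (0.18 log units; within the scatter), put 3,5-dimethylphenyl in place of 2-iodophenyl on a carbonyl carbon. Compound 3 shows the lowest of the three numbers; against compound 2 the gap is within the scatter, while against compound 1 it is beyond it.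

Compound 4 `Cc1cccc(C(=O)NN(C(=O)c2ccccc2Cl)C(C)(C)C)c1` differs from compound 3 by 3-methylphenyl in place of 2-fluorophenyl on a carbonyl carbon. Going by the values given here, the only measured step that bears on this change is the one from compound 1 to compound 2, which likewise traded a 2-halogenated ring for a methyl-bearing ring on a carbonyl carbon and stayed within the scatter. On that basis a change of no more than the scatter is expected in this assay, with no clear direction. For compound 4 the estimated value in this assay is 50 nM, within a range from 20 nM to 130 nM, so that the expected step of a 1.0-fold lower number from compound 3 to compound 4 (0.01 log units; within the scatter) is essentially flat.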

Compound 4, half-maximal effective concentration: 603 nM
For compound 4 the middle estimate is 12-fold (1.08 log units) below the measured one; measured number above the stated range.
By their numbers in this assay, from the lowest: compounds 3, 2 and 1 (each within the scatter of the next, the first and the last beyond it); then compound 4.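

The ring on this carbonyl carbon proves to matter in this assay: a 12-fold higher number from compound 3 to compound 4 (1.07 log units; beyond the scatter), and this exchange of 2-fluorophenyl for 3-methylphenyl leaves compound 4 apart from the other three compounds. The earlier step, a 1.5-fold lower number from compound 1 to compound 2 (0.18 log units; within the scatter), had shown no change beyond the scatter, so the new result shows that a swap between a halogen-bearing ring and a methyl-bearing ring on a carbonyl carbon does not carry a single outcome across this series. Nothing at hand accounts for the size of the step, as no measurement bears on why these two rings differ so much.

The compounds shown do not separate the loss of the fluorine from the arrival of the methyl, since both rings have the same number of heavy atoms and the step exchanges the two substituents in one move. They also leave open how this carbonyl carbon would respond to a ring carrying a methoxy group, an amine or a carboxylic acid, and whether any such ring would bring the number back towards that of compound 3.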